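The source may report more compounds than this note shows. Statements on the series, on what has been measured and on what is new or still open speak of the compounds shown alone.

Compound 2 `CN(C(=O)NC(=O)c1ccccc1F)c1nc(C(F)(F)F)c(C(=O)N/N=C/c2ccccc2C(F)(F)F)s1` carries a ((2-fluorophenyl)carbonyl)carbamoyl group on a nitrogen on an aromatic ring of its core. For the measured compounds named here, in a functional assay on BCG823 cells (Homo sapiens) for inhibition, read by MTT assay, with a stated time of 72 h (on this read-out higher numbers stand for weaker inhibition and lower numbers for stronger inhibition), compound 2 gives 4.67 ug/mL, which is the only number measured here. Compound 1 `CNc1nc(C)c(C(=O)N/N=C/c2ccccc2C(F)(F)F)s1` is a close relative of the same core. In this assay compound 1 gives > 100 ug/mL, a limit of the assay rather than a number. Compound 3 `CNc1nc(C(F)(F)F)c(C(=O)N/N=C/c2ccccc2C(F)(F)F)s1` has not yet been measured; it differs from compound 2 by hydrogen in place of ((2-fluorophenyl)carbonyl)carbamoyl on a nitrogen on an aromatic ring. Going by the values given here, no measured pair shows this change, so its size must be guessed. The step from compound 2 to compound 3 is expected to weaken inhibition beyond the usual scatter, by a 13-fold higher number from compound 2 to compound 3 (1.11 log units; beyond the scatter), partly because compound 1 sits at the limit of > 100 ug/mL in this assay, at which 1 of the 2 values shown sits. Compound 3 is therefore expected to give about 60 ug/mL in this assay, within a range from 15 ug/mL to 200 ug/mL, and a limit rather than a number would not surprise.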

Compound 3, half-maximal inhibitory concentration: > 100 ug/mL
Compound 3: a limit, no number; the forecaster's own chance of this, stated with the estimate: 55%; middle value at least 1.6-fold (0.22 log units) from the limit.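

Replacing the ((2-fluorophenyl)carbonyl)carbamoyl group on the nitrogen with hydrogen gives an at least 21-fold higher number from compound 2 to compound 3 (1.33 log units; beyond the scatter) in this assay. For the compounds shown here, this is the first pair that differs only at this nitrogen, so the measurable value of compound 2 can now be tied to this one group, and not to the trifluoromethyl that replaces methyl on the aromatic carbon in compound 1. Compound 3 gives a limit and not a number, so the true size of the step is unknown and could be larger: the limit of > 100 ug/mL in this assay, at which 2 of the 3 values shown sit.

The step from methyl to trifluoromethyl between compound 1 and compound 3 cannot be read, as both values are limits. Also open, from the compounds shown here alone, is which part of the large group matters: a simple acetyl or an unsubstituted carbamoyl on this nitrogen, or a benzoyl carbamoyl without the fluorine, would begin to show this.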